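A few compounds are considered here, and "the series" means these few. Any claim that something is new, unique, unknown or untested is made for them only; others in the source may bear on it.

Values in an ADME assay for permeability, with a stated time of 2 h (on this read-out higher numbers stand for higher permeability and lower numbers for lower permeability), for three compounds that share one core:

- compound 1 `Nc1cc(Oc2ccc(NC(=O)Nc3cccc(C(F)(F)F)c3)cc2)ncn1` gives 245 nm/s
- compound 2 `CNc1cc(Oc2ccc(NC(=O)Nc3cccc(C(F)(F)F)c3)cc2)ncn1` gives 230 nm/s
- compound 3 `CC(C)(O)CNc1cc(Oc2ccc(NC(=O)Nc3cccc(C(F)(F)F)c3)cc2)ncn1` gives 210 nm/s

Compound 3 at 210 nm/s sits within the usual scatter of both compound 1 and compound 2. The next compound to be measured is compound 4 `O=C(Nc1ccc(Oc2cc(NCCO)ncn2)cc1)Nc1cccc(C(F)(F)F)c1` and the change leading to it is hydroxymethyl in place of 1-hydroxy-1-methylethyl on a saturated chain carbon bound to a nitrogen on an aromatic ring in which hydroxymethyl takes the place of 1-hydroxy-1-methylethyl on a saturated chain carbon bound to a nitrogen on an aromatic ring. Among the measured compounds shown here, no measured step makes this exact swap, but three steps alter the group on that same nitrogen. They are a 1.1-fold lower number from compound 1 to compound 2 (0.03 log units; within the scatter) and a 1.2-fold lower number from compound 1 to compound 3 (0.07 log units; within the scatter) and also a 1.1-fold lower number from compound 2 to compound 3 (0.04 log units; within the scatter) and all of them stay within the scatter. Going by these small steps, the step expected in this assay is a 1.0-fold higher number from compound 3 to compound 4 (0.01 log units; within the scatter) and no shift beyond the scatter is expected in either direction. For compound 4 the estimate is 215 nm/s with an expected range from 130 nm/s to 350 nm/s on this read-out.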

Compound 4, apparent permeability: 82 nm/s
The estimate for compound 4 lay 2.6-fold (0.42 log units) above the measured number; the measured number lies below the stated range.
By their numbers in this assay, from the lowest: compound 4; then compounds 3, 2 and 1 (each within the scatter of the next).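

Going from 2-hydroxy-2-methylpropyl to 2-hydroxyethyl on this nitrogen gives the first step beyond the scatter in this assay (a 2.6-fold lower number from compound 3 to compound 4 (0.41 log units; beyond the scatter)), even though the two groups carry the same counts of hydrogen-bond donors and acceptors. Compound 4 also falls short of the compounds with a smaller group on that nitrogen, methyl (a 2.8-fold lower number from compound 2 to compound 4 (0.45 log units; beyond the scatter)) and hydrogen (a 3.0-fold lower number from compound 1 to compound 4 (0.48 log units; beyond the scatter)). The position is therefore not indifferent to what it carries, and a hydroxyl on the chain does not by itself set the number, since compound 3 also has one yet stays within the scatter of compounds 1 and 2.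

Nothing measured here explains the lower number for compound 4. Still open, on these data alone, is how the number would respond to a 2-hydroxypropyl chain, with a single methyl, or to a 2-methoxyethyl or 2-aminoethyl group on this nitrogen.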